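Swapping the methoxyphenyl ring for a thiophene

A few compounds are considered here, and "the series" means these few. Any claim that something is new, unique, unknown or untested is made for them only; others in the source may bear on it.

Of the compounds shown here, three sharing one core have been tested in an ADME assay on Huh-7 cells (Homo sapiens) for cytotoxicity; a higher number here means that more compound is tolerated, a lower number that less compound is tolerated. Compound 1 `O=C(NC(=S)N1CCc2c(OCCCCCOc3ccc(Cl)cc3)cccc21)c1cccc([N+](=O)[O-])c1` gives 12100 nM. Compound 2 `O=C(NC(=S)N1CCc2c(OCCCCCOc3ccc(Cl)cc3)cccc21)c1ccc(F)cc1` gives 31100 nM, and compound 3 `COc1ccc(C(=O)NC(=S)N2CCc3c(OCCCCCOc4ccc(Cl)cc4)cccc32)cc1` gives 34400 nM. Compound 3 and compound 2 cannot be told apart on these numbers, since the step of a 1.1-fold higher number from compound 2 to compound 3 (0.04 log units; within the scatter) lies within the scatter. Against compound 1 the picture is different: the steps of a 2.6-fold higher number from compound 1 to compound 2 (0.41 log units; beyond the scatter) and a 2.8-fold higher number from compound 1 to compound 3 (0.45 log units; beyond the scatter) are both beyond the scatter, so compound 3 is among the better-tolerated members of this small set.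

Compound 4 `O=C(NC(=S)N1CCc2c(OCCCCCOc3ccc(Cl)cc3)cccc21)c1ccsc1` differs from compound 3 in one place: thiophen-3-yl in place of 4-methoxyphenyl on a carbonyl carbon. Within the data shown here, no measured step brings in a thiophen-3-yl, so the only guidance comes from the two exchanges of the ring on the carbonyl carbon, a 2.6-fold higher number from compound 1 to compound 2 (0.41 log units; beyond the scatter) and a 2.8-fold higher number from compound 1 to compound 3 (0.45 log units; beyond the scatter), both modest, and from a 1.1-fold higher number from compound 2 to compound 3 (0.04 log units; within the scatter), which stays within the scatter. Exchanging that ring has so far shifted this assay only modestly at most. For compound 4 a step of a 1.2-fold lower number from compound 3 to compound 4 (0.09 log units; within the scatter) is therefore expected, small and within the scatter. Compound 4 is estimated at 28000 nM, with a range from 12000 nM to 60000 nM.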

Compound 4, half-maximal cytotoxic concentration: > 50000 nM
Compound 4 ended at the assay's limit; the forecaster's own chance of this, stated with the estimate: 5%; at least 1.7-fold (0.25 log units) between middle value and limit.
By their numbers in this assay, from the lowest: compound 1; then compounds 2 and 3 (each within the scatter of the next). At a limit, above all of these: compound 4.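

In this assay compound 4 gives > 50000 nM, which is a limit of the assay and not a number. Among these compounds, this is the first sign that the ring on the carbonyl carbon need not be a six-membered aromatic ring of carbon only, as a five-membered ring with a sulfur atom is also tolerated here: the exchange for the nitro-bearing ring gives an at least 4.1-fold higher number from compound 1 to compound 4 (0.61 log units; beyond the scatter), while the other two exchanges give an at least 1.4-fold higher number from compound 3 to compound 4 (0.16 log units; that floor lies within the scatter) and an at least 1.6-fold higher number from compound 2 to compound 4 (0.20 log units; that floor lies within the scatter), so only the first of these floors clears the scatter, and compound 4 cannot yet be ranked against compound 2 or compound 3. All three steps are only floors, because compound 4 stands at a limit: the limit of > 50000 nM in this assay, at which 1 of the 4 values shown sits.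

The compounds shown leave open whether the sulfur atom or the smaller ring size goes with this result, a question that a furan-3-yl ring, with oxygen in place of sulfur, or a thiophen-2-yl ring could help to settle. They also leave open whether the ring on the carbonyl carbon must be aromatic at all, as a saturated cyclohexyl ring would show.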